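Compound 4: a 5-chloropyridin-2-yl amide

This account rests on a few compounds, and the source may have more. Where it says the series, first, only, none or still open, it means among the compounds named here.

In an in vitro ADME assay on microsomes from liver (Mus musculus) for pharmacokinetics, read by LC-MS, with a stated time of 10 min, tested at 1 uM (a lower number here means slower removal, a higher number faster removal of the compound), compound 1 `CN1C[C@H](C(=O)Nc2ccc(F)c(Cl)c2)[C@@H](c2ccc(/C=C/C(=O)Nc3ccccc3N)cc2)C1` gives 34 mL/min/kg and compound 2 `Cc1cc(NC(=O)[C@H]2CN(C)C[C@@H]2c2ccc(/C=C/C(=O)Nc3ccccc3N)cc2)ccc1F` gives 62 mL/min/kg, while compound 3 `Cc1cc(NC(=O)[C@H]2CN(C)C[C@@H]2c2ccc(/C=C/C(=O)Nc3ccccc3N)cc2)ccc1Cl` stands at 65 mL/min/kg within the scatter of both. Compound 4 `CN1C[C@H](C(=O)Nc2ccc(Cl)cn2)[C@@H](c2ccc(/C=C/C(=O)Nc3ccccc3N)cc2)C1` carries one change, 5-chloropyridin-2-yl in place of 4-chloro-3-methylphenyl on an amide-type nitrogen in short 5-chloropyridin-2-yl in place of 4-chloro-3-methylphenyl on an amide-type nitrogen. For the measured compounds named here, the steps that bear on it fall on that same group: a 1.8-fold higher number from compound 1 to compound 2 (0.26 log units; within the scatter), a 1.9-fold higher number from compound 1 to compound 3 (0.28 log units; within the scatter) and a 1.0-fold higher number from compound 2 to compound 3 (0.02 log units; within the scatter) all stay within the scatter. Going by the values given here, no measured compound has a hetero atom in that ring, so the guide is thin. No step beyond the scatter is therefore expected in this assay in either direction. The estimated change is a 1.3-fold lower number from compound 3 to compound 4 (0.11 log units; within the scatter) at most a modest one. For compound 4 the estimated value is 50 mL/min/kg with an expected range of 25 mL/min/kg to 95 mL/min/kg around it.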

Compound 4, clearance: 31 mL/min/kg
Compound 4: middle estimate off by 1.6-fold (0.21 log units), on the high side; measured number inside the range.
By their numbers in this assay, from the lowest: compounds 4, 1, 2 and 3 (each within the scatter of the next, the first and the last beyond it).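

In this assay, for the compounds shown here, 5-chloropyridin-2-yl, the first ring here with a hetero atom, gives the first step at this position beyond the scatter (a 2.1-fold lower number from compound 3 to compound 4 (0.32 log units; beyond the scatter)). The other two comparisons stay within the scatter (a 2.0-fold lower number from compound 2 to compound 4 (0.30 log units; within the scatter); a 1.1-fold lower number from compound 1 to compound 4 (0.04 log units; within the scatter)), so this group reads level with 3-chloro-4-fluorophenyl and 4-fluoro-3-methylphenyl. No measurement shown explains the step.

From the compounds shown here alone, the change also removes the methyl of 4-chloro-3-methylphenyl, so the share of the ring nitrogen stays open. Going by these compounds, how 5-fluoropyridin-2-yl or 5-methylpyridin-2-yl would read also stays open.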